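A few compounds are considered here, and "the series" means these few. Any claim that something is new, unique, unknown or untested is made for them only; others in the source may bear on it.

Measured so far:
- compound 1, `Cc1cc2ccccc2nc1-c1cn(CCC(F)(F)C(F)(F)C(F)(F)C(F)(F)C(F)(F)C(F)(F)C(F)(F)C(F)(F)F)nn1`: > 100 ug/mL
- compound 2, `CCCCCCCCCCn1cc(-c2nc3ccccc3cc2CC)nn1`: 34.3 ug/mL
- compound 3, `CCc1cc2ccccc2nc1-c1cn(-c2ccc(F)cc2)nn1`: > 100 ug/mL

In a functional assay on THP-1 cells (Homo sapiens) for cytotoxicity, read by MTT assay, with a stated time of 24 h (on this read-out higher numbers stand for weaker inhibition and lower numbers for stronger inhibition), only compound 2 gives a number, 34.3 ug/mL. For compound 1 the read-out is a limit of the assay, > 100 ug/mL, not a number. For compound 3 the read-out is likewise a limit, > 100 ug/mL. For the measured compounds named here, two of the three values therefore sit at the limit of > 100 ug/mL in this assay, at which 2 of the 3 values shown sit, and compound 2 stands alone as the one compound with a measured concentration in this assay; no pairwise step between measured compounds differs in a single place, so no step size has been observed.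

Compound 4, `CCCCCCCCCCn1cc(-c2nc3ccccc3cc2CCCCC)nn1`, is not yet measured. It differs from compound 2 by propyl in place of hydrogen on a saturated chain carbon, two bonds along the chain from an aromatic carbon; cut one bond further out, the change reads ethyl to pentyl on the shared core, with the decyl chain and the rest of compound 2 kept.

Going by the values given here, with no measured step of this kind to lean on, the step from compound 2 to compound 4 is expected to be small, a 1.4-fold lower number from compound 2 to compound 4 (0.14 log units; within the scatter), a slight move toward a lower number in this assay that may not exceed the scatter. Compound 4 is accordingly estimated at 25 ug/mL, with a range from 10 ug/mL to 70 ug/mL.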

Compound 4, half-maximal inhibitory concentration: 88 ug/mL
Compound 4: the middle estimate sits 3.5-fold (0.55 log units) below what was measured, and the stated range ends below it.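

In this assay, for the compounds shown here, the change of ethyl to pentyl on the shared core, with the decyl chain kept, gives a 2.6-fold higher number from compound 2 to compound 4 (0.41 log units; beyond the scatter), the only step that can be read so far. The position therefore responds to chain length: propyl in place of hydrogen on a saturated chain carbon, two bonds along the chain from an aromatic carbon, goes with weaker inhibition in this pair, by a modest step beyond the scatter. Compound 4, at 88 ug/mL, now stands near the top of the measurable range of this assay: the limit of > 100 ug/mL in this assay, at which 2 of the 4 values shown sit.

A single step gives a direction for this pair only, and it leaves open whether a butyl group at this position would fall on the same line or whether a longer chain, such as heptyl, would carry the number further up to the limit. Also open, going by these compounds, is whether a terminal hydroxyl or an amine on this chain would give a different result, and whether the ethyl-to-pentyl step holds when the decyl chain is replaced.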